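This account rests on a few compounds, and the source may have more. Where it says the series, first, only, none or still open, it means among the compounds named here.

Of the compounds shown here, three built on a shared core have been measured in an assay on HEK293 cells for displacement of a labelled ligand from 5-hydroxytryptamine receptor 7 (Homo sapiens); a higher number here means a weaker inhibitor, a lower number a stronger inhibitor. Compound 1 `O=c1[nH]c2ccccc2n1CCCCCCN1CCN(c2ccccc2)CC1` gives 20 nM. Compound 2 `COc1ccccc1N1CCN(CCCCCn2c(=O)[nH]c3ccccc32)CC1` gives 38 nM, a number within the usual scatter of that for compound 1, so the two cannot be told apart. Compound 3 `COc1cccc(-n2c(=O)n(CCN3CCN(c4ccccc4C)CC3)c3ccccc32)c1` gives 2500 nM, which lies far above the number for compound 2 and well beyond the scatter, so compound 2 stands second highest of the three. The unmeasured compound 4 `O=c1[nH]c2ccccc2n1CCCCCN1CCN(c2cccc(Cl)c2)CC1` differs from compound 2 only by 3-chlorophenyl in place of 2-methoxyphenyl on an amine nitrogen in a ring. Among the compounds with values here, no measured pair shows this particular change, so its size is unknown. A step of a 1.1-fold higher number from compound 2 to compound 4 (0.02 log units; within the scatter) is expected, staying within the scatter. Compound 4 is therefore expected to give about 40 nM, with a range from 12 nM to 130 nM.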

Compound 4, inhibition constant: 11 nM
Compound 4: middle estimate off by 3.6-fold (0.56 log units), on the high side; measured number below the stated range.
By their numbers in this assay, from the lowest: compounds 4, 1 and 2 (each within the scatter of the next, the first and the last beyond it); then compound 3.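

In this assay, 3-chlorophenyl in place of 2-methoxyphenyl on the amine nitrogen in the ring gives a 3.5-fold lower number from compound 2 to compound 4 (0.54 log units; beyond the scatter). Within the data shown here, this is the first step read at this place, and it shows that the number responds, modestly, to which aryl group the nitrogen carries. Nothing shown gives a reason for this step.

Still open, from the compounds shown here alone, is whether the step follows from the chlorine, from where it sits on the phenyl ring, or from the loss of the methoxy group. Placing 2-chlorophenyl or 3-methoxyphenyl on this nitrogen, with the rest of compound 2 unchanged, would help separate these.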